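The source may hold more compounds than are shown below. What is called first, only, known or untested is meant among the compounds shown, and "the series" means these compounds.

Measured so far:
- compound 1 `CN1CCC[C@@H]1Cn1nc(Cc2cccc(Cl)c2)c2ccccc2c1=O`: 398 nM
- compound 2 `CN1CCCCC(n2nc(Cc3ccc(Cl)cc3)c3ccccc3c2=O)C1`: 158 nM

In an assay for binding affinity to Alpha-1A adrenergic receptor (Homo sapiens) (a higher number here means a weaker inhibitor, a lower number a stronger inhibitor), compound 1 holds the higher of the two numbers; compound 2 sits a step below it, and that gap is beyond the usual scatter. Within the data shown here, compound 1 and compound 2 differ in more than one place, so no single step between them is set out, and the two values are taken only as what they are.

Compound 3 `CN1CCC[C@@H]1Cn1nc(Cc2ccc(F)cc2)c2ccccc2c1=O` differs from compound 1 in one place: 4-fluorophenyl in place of 3-chlorophenyl on a saturated chain carbon bound to an aromatic carbon. Among the measured compounds shown here, no measured pair shows this exchange alone. The expectation is for a step from compound 1 to compound 3 of a 1.1-fold lower number from compound 1 to compound 3 (0.06 log units; within the scatter) in this assay, with no direction held beyond the scatter. In this assay compound 3 is estimated at 350 nM, within 120 nM to 1000 nM.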

Compound 3, inhibition constant: 63.1 nM
Compound 3: middle estimate off by 5.5-fold (0.74 log units), on the high side; the measured number lies below the stated range.
By their numbers in this assay, from the lowest: compound 3; then compound 2; then compound 1.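

The aryl group on this saturated chain carbon is a position that this assay responds to: 4-fluorophenyl in place of 3-chlorophenyl gives a 6.3-fold lower number from compound 1 to compound 3 (0.80 log units; beyond the scatter). The change matters even though the two groups match in heavy-atom count, aromatic ring and hydrogen-bond donor and acceptor counts, so those counts do not track the step. No supporting data bear on why the exchange has this size.

This single exchange changes both the halogen and where it stands, so the two changes cannot be told apart; 3-fluorophenyl or 4-chlorophenyl on the core of compound 1 would separate them. Also open, as far as these compounds go, is how a group without halogen, such as 4-methoxyphenyl or unsubstituted phenyl, would compare with 4-fluorophenyl in this place.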